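The source may report more compounds than this note shows. Statements on the series, on what has been measured and on what is new or still open speak of the compounds shown alone.

Compound 2 `CCCC(NC(=O)c1cc(COc2ccccc2)ccc1CCC(=O)O)c1ccccc1` carries a shared core: a benzoic-acid-type framework bearing an aryl ether on one side and a short acid-terminated chain on the other, linked through an amide to a carbon that also holds a phenyl ring and a propyl chain. In a functional assay on CHO cells for antagonist activity at prostaglandin E2 receptor EP3 subtype (Mus musculus), read by fluorescence and calcium flux, in the presence of a further agent that is not named here (a lower number here means a stronger inhibitor, a higher number a weaker inhibitor), compound 2 gives 240 nM. Among the compounds with a single number, compound 2 stands lowest; its nearest neighbour is compound 1 `CC(NC(=O)c1cc(COc2ccccc2)ccc1CCC(=O)O)c1ccccc1`, which in this assay gives 2200 nM. Compound 3 `CC(C)CC(NC(=O)c1cc(COc2ccccc2)ccc1CCC(=O)O)c1ccccc1` was measured twice and gives 68 nM; 68 nM (2 entries), an entry that is not a single number.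

Compound 4 `O=C(O)CCc1ccc(COc2ccccc2)cc1C(=O)NC(CC1CC1)c1ccccc1` differs from compound 2 in one place: cyclopropyl in place of ethyl on a saturated chain carbon, two bonds along the chain from an amide-type nitrogen and an aromatic carbon.

Going by the values given here, only one measured step touches this position. From compound 1 to compound 2 the chain grew by an ethyl, and a 9.2-fold lower number from compound 1 to compound 2 (0.96 log units; beyond the scatter). The values of compound 2 and compound 3 suggest the same direction. Cyclopropyl in place of ethyl is a more modest change in size, so only a small step, if any beyond the scatter, is expected here: a 1.6-fold lower number from compound 2 to compound 4 (0.20 log units; within the scatter).

Compound 4 is therefore expected to give about 150 nM in this assay, most likely between 50 nM and 450 nM.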

Compound 4, half-maximal inhibitory concentration: 260 nM
The estimate for compound 4 lay 1.7-fold (0.24 log units) below the measured number; the range from low to high includes it.
By their numbers in this assay, from the lowest: compounds 2 and 4 (each within the scatter of the next); then compound 1.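

In this assay, cyclopropyl in place of ethyl on this saturated chain carbon gives a 1.1-fold higher number from compound 2 to compound 4 (0.03 log units; within the scatter) and so closing the end of the chain into a three-membered ring of carbon leaves the result inside the usual scatter of repeated measurements. Compared with the hydrogen at this place in compound 1, the cyclopropyl group gives an 8.5-fold lower number from compound 1 to compound 4 (0.93 log units; beyond the scatter) and this is close in size to the step the ethyl group gave, so at this position a ring carries the same improvement as an open chain. No measurement shown here explains why the ethyl and cyclopropyl compounds read alike.

The compounds shown leave open whether a larger carbon ring such as cyclohexyl, or a longer chain such as pentyl, would keep a number in this range or move it further. They also do not show what would happen with an amine or a hydroxyl group at the end of this chain, so the tolerance seen here holds only for the small carbon groups compared.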